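Bromo to methoxy in a Vero cell toxicity test

The compounds below may be only part of what the source reports. "The series", "measured", "known", "first", "only" and "open" are said of these compounds alone.

Compound 1 `CC1(C)O[C@H]2O[C@H](Cn3cc(CN4C(=O)C(=O)c5ccccc54)nn3)[C@H](O)[C@H]2O1` gives > 200000 nM (a limit of the test)
Compound 2 `CC1(C)O[C@H]2O[C@H](Cn3cc(CN4C(=O)/C(=N\Nc5ccccc5)c5ccccc54)nn3)[C@H](O)[C@H]2O1` gives 82100 nM
Compound 3 `CC1(C)O[C@H]2O[C@H](Cn3cc(CN4C(=O)/C(=N\Nc5ccc(Br)cc5)c5ccccc54)nn3)[C@H](O)[C@H]2O1` gives 72900 nM

All three values come from an ADME assay on Vero cells (Chlorocebus sabaeus) for cytotoxicity, read by fluorescence and resazurin assay, with a stated time of 3 days (on this read-out lower numbers stand for higher toxicity in this test and higher numbers for lower toxicity in this test), and share one core. Compound 1 stands at a limit rather than a number, as the note the limit of > 200000 nM in this assay, at which 1 of the 3 values shown sits, records. Only compound 2 and compound 3 carry true numbers, and these two lie within the scatter of each other, so compound 3 stands level with compound 2.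

The next compound, compound 4 `COc1ccc(N/N=C2\C(=O)N(Cc3cn(C[C@H]4O[C@@H]5OC(C)(C)O[C@@H]5[C@H]4O)nn3)c3ccccc32)cc1`, differs from compound 3 in one group: methoxy in place of bromo on an aromatic carbon. Methoxy takes the place of bromo on an aromatic carbon, para to a large group.

For the measured compounds named here, one measured step bears on this change, the swap of hydrogen for bromo on an aromatic carbon: a 1.1-fold lower number from compound 2 to compound 3 (0.05 log units; within the scatter). That single step stayed within the scatter, so it offers no reason to expect a real shift. Methoxy itself has not yet been tested here, which leaves the evidence thin. The expected change is small, no more than scatter: a 1.1-fold higher number from compound 3 to compound 4 (0.03 log units; within the scatter). Compound 4 is estimated at 78000 nM in this assay, with an expected range of 40000 nM to 150000 nM.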

Compound 4, half-maximal cytotoxic concentration: 74500 nM
Estimate against measurement, compound 4: 1.0-fold (0.02 log units) above; the measured number falls inside the stated range.
By their numbers in this assay, from the lowest: compounds 3, 4 and 2 (each within the scatter of the next). At a limit, above all of these: compound 1.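

At this position, on an aromatic carbon para to a large group, methoxy in place of bromo gives a 1.0-fold higher number from compound 3 to compound 4 (0.01 log units; within the scatter) in this assay even though two heavy atoms and a hydrogen-bond acceptor replace a single heavy atom. Measured against hydrogen at the same position, methoxy gives a 1.1-fold lower number from compound 2 to compound 4 (0.04 log units; within the scatter) and so adds a second substituent to bromo that leaves the reading within the scatter of the unsubstituted phenyl compound, which means that this test has not yet separated hydrogen, bromo and methoxy on this ring. None of the measurements shown speaks to why these three groups read alike.

The compounds shown leave open whether an amine or a carboxylic acid at this position would produce a step beyond the scatter in this assay where these three groups have not. Also open, from the compounds shown here alone, is whether a longer chain, such as a butoxy group in place of methoxy, would keep the reading level or finally move it.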